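A Methyl Added to the Sulfur Compound

A few compounds are considered here, and "the series" means these few. Any claim that something is new, unique, unknown or untested is made for them only; others in the source may bear on it.

compound 1 `COc1cc(-c2cc(=O)[nH]c3c(O)c(OC)ccc23)cc([Se]C)c1OC` 22 nM
compound 2 `COc1cc(-c2cc(=O)[nH]c3c(O)c(OC)ccc23)cc(SC)c1OC` 51.7 nM

Among the compounds with values here, of the two numbers measured in a functional assay on HepG2 cells (Homo sapiens) for inhibition, read by MTT assay, with a stated time of 48 h (a higher number here means a weaker inhibitor, a lower number a stronger inhibitor), the higher belongs to compound 2 at 51.7 nM and compound 1 is its only neighbour. Within the data shown here, the single measured step is a 2.4-fold higher number from compound 1 to compound 2 (0.37 log units; beyond the scatter) and it records sulfur in place of selenium, a modest move at another place on the shared core. It therefore offers no direct guide here. Among the measured compounds shown here, compound 3 `COc1cc(-c2c(C)c(=O)[nH]c3c(O)c(OC)ccc23)cc(SC)c1OC` is compound 2 with methyl in place of hydrogen on an aromatic carbon and no measured pair changes that place. With so little to go on, a modest rise is expected, though with wide uncertainty. The expected move is a 2.1-fold higher number from compound 2 to compound 3 (0.33 log units; beyond the scatter) and it remains a loose estimate. The estimate for compound 3 is 110 nM and the expected range runs from 25 nM to 500 nM for that compound.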

Compound 3, half-maximal inhibitory concentration: 303 nM
Beside the measured number, compound 3's estimate is 2.8-fold (0.44 log units) below it; low and high end bracket the measured number.
By their numbers in this assay, from the lowest: compound 1; then compound 2; then compound 3.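

In this assay, methyl in place of hydrogen gives a 5.9-fold higher number from compound 2 to compound 3 (0.77 log units; beyond the scatter), so this position on the shared core does respond to a change, which the sulfur and selenium pair could not show. Of the two groups seen on this aromatic carbon, two atoms from the ring nitrogen, hydrogen goes with the lower number, and a single added carbon is enough to produce a step beyond the scatter. Nothing available here accounts for the rise.

The compounds shown leave open whether the rise is particular to methyl or would also follow from a longer chain such as ethyl, a chlorine atom or an amine on this carbon. They also leave open whether methyl at this place would move the number of the selenium compound 1 by a similar amount.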